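A few compounds are considered here, and "the series" means these few. Any claim that something is new, unique, unknown or untested is made for them only; others in the source may bear on it.

Measured compounds:
- compound 1, `COCc1ccc(-c2ccc3nnc(C(N)=O)c(N[C@@H](C)C4CCOCC4)c3c2)cn1`: 5.6 uL/min
- compound 2, `CNC(=O)c1nnc2ccc(-c3ccc(COC)nc3)cc2c1N[C@@H](C)C1CCOCC1`: 5.8 uL/min
- compound 3, `C[C@H](Nc1c(C(N)=O)nnc2ccc(-c3ccc(OCCCN4CCCC4)nc3)cc12)C1CCOCC1`: 1.9 uL/min

In an ADME assay on cells (Hepatocyte, Rattus norvegicus) for metabolic stability, read by HPLC, with a stated time of 30 min, tested at 1 uM (on this read-out higher numbers stand for fast clearance and lower numbers for slow clearance), compound 2 gives the highest of the three numbers, but compound 1 sits so close that the two cannot be told apart; compound 3 is the one that stands clearly apart, at a lower number. The unmeasured compound 4, `CNC(=O)c1nnc2ccc(-c3ccc(OCCCN(C)C)nc3)cc2c1N[C@@H](C)C1CCOCC1`, is reached from compound 2 by one change: 3-(dimethylamino)propoxy in place of methoxymethyl on an aromatic carbon. Among the compounds with values here, of the measured steps, the one from compound 1 to compound 3 is the closest guide, since it also swaps the methoxymethyl for a propoxy chain ending in an amine, and it gave a 2.9-fold lower number from compound 1 to compound 3 (0.47 log units; beyond the scatter). The other step, a 1.0-fold higher number from compound 1 to compound 2 (0.02 log units; within the scatter), shows that the methyl on the amide nitrogen shared by compound 2 and compound 4 does not move this read-out. A modest downward step is therefore expected, of about a 2.9-fold lower number from compound 2 to compound 4 (0.46 log units; beyond the scatter). Compound 4 is estimated at 2 uL/min, with a likely range from 1 uL/min to 4 uL/min.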

Compound 4, intrinsic clearance in a liver preparation (reported as CLH), per the amount of preparation that the assay uses in the Hepatocyte assay: 5.7 uL/min
Compound 4: middle estimate off by 2.9-fold (0.45 log units), on the low side; the whole stated range lies below it.
By their numbers in the Hepatocyte assay, from the lowest: compound 3; then compounds 1, 4 and 2 (each within the scatter of the next).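

With the methyl on the amide nitrogen in place, putting 3-(dimethylamino)propoxy on this aromatic carbon, next to the ring nitrogen, leaves clearance level in the Hepatocyte assay: a 1.0-fold lower number from compound 2 to compound 4 (0.01 log units; within the scatter). An amine-ended propoxy chain at this position therefore does not always go with the lower number seen in the other such step, a 2.9-fold lower number from compound 1 to compound 3 (0.47 log units; beyond the scatter). In a physicochemical assay for lipophilicity, using the shake flask method, measured as octanol-water partition, with a stated time of 30 min, at pH 7.4 (on this read-out higher numbers stand for higher lipophilicity and lower numbers for lower lipophilicity), compound 2 gives 3 and compound 4 gives 2.3, a gap beyond the scatter, so the two read-outs do not move together for this pair.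

Still open, from the compounds shown here alone, is whether the different outcomes of the two steps trace to the amide methyl or to the amine at the chain end, as the two steps differ in both. How a morpholine or a carboxylic acid at the end of the propoxy chain would behave on clearance is also unknown.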